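Swapping chloro for trifluoromethyl on the benzyl arm

A few compounds are considered here, and "the series" means these few. Any claim that something is new, unique, unknown or untested is made for them only; others in the source may bear on it.

Compound 1 `O=C(NCc1cn(Cc2ccc(Cl)cc2)nn1)c1cn(-c2ccccc2)nc1-c1ccc(F)cc1` gives 130 nM in a functional assay on MCF7 cells (Homo sapiens) for antiproliferative activity, read by sulforhodamine B assay, with a stated time of 48 h (a lower number here means a stronger inhibitor of growth, a higher number a weaker inhibitor of growth), and is the reference point for this small set. Compound 2 `O=C(NCc1cn(Cc2ccc(C(F)(F)F)cc2)nn1)c1cn(-c2ccccc2)nc1-c1ccc(F)cc1` differs from it only at the benzyl end, where (trifluoromethyl in place of chloro on an aromatic carbon). That single exchange is measured as a 6.2-fold higher number from compound 1 to compound 2 (0.79 log units; beyond the scatter), so compound 2, at 810 nM, is a weaker inhibitor of growth than compound 1.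

Compound 3 `COc1ccc(-c2nn(-c3ccccc3)cc2C(=O)NCc2cn(Cc3ccc(Cl)cc3)nn2)cc1` keeps the chloro on the benzyl arm but changes the aryl group on the shared core: methoxy in place of fluoro on an aromatic carbon. In this assay compound 3 gives 2900 nM, which is a 22-fold higher number from compound 1 to compound 3 (1.35 log units; beyond the scatter), and compound 3 has the highest number of the three measured compounds, every step to the others lying beyond the scatter.

Compound 4 `COc1ccc(-c2nn(-c3ccccc3)cc2C(=O)NCc2cn(Cc3ccc(C(F)(F)F)cc3)nn2)cc1` is not yet measured. It stands to compound 3 exactly as compound 2 stands to compound 1: trifluoromethyl in place of chloro on an aromatic carbon, the same change at the same place, made this time on the methoxy-bearing core. Among the compounds with values here, the only guide to its effect is the measured pair, where the step was a 6.2-fold higher number from compound 1 to compound 2 (0.79 log units; beyond the scatter). The author therefore expects a step of about a 5.2-fold higher number from compound 3 to compound 4 (0.71 log units; beyond the scatter) in this assay, resting on that single earlier pair and on the value of compound 3, 2900 nM. As far as these compounds go, whether the change behaves the same way on a weaker core is unknown, so the range is kept wide. Compound 4 is estimated at 15000 nM in this assay, expected to fall between 5000 nM and 45000 nM.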

Compound 4, concentration for 50% growth inhibition: > 100000 nM
Compound 4: no number, only a limit (the forecaster's own chance of this, stated with the estimate: 20%); middle value at least 6.6-fold (0.82 log units) from the limit.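

In this assay compound 4 gives > 100000 nM, which is a limit of the assay and not a number: the limit of > 100000 nM in this assay, at which 1 of the 4 values shown sits. Trifluoromethyl in place of chloro weakens growth inhibition on both cores, but the step on the methoxy-bearing core, an at least 34-fold higher number from compound 3 to compound 4 (1.53 log units; beyond the scatter), is larger than on the fluoro-bearing core, so the size of this change did not carry over from one core to the other: the same change on two cores in this assay, a 6.2-fold higher number (0.79 log units; beyond the scatter) from compound 1 to compound 2 and an at least 34-fold higher number (1.53 log units; beyond the scatter) from compound 3 to compound 4, at least 5.5-fold (0.74 log units) apart, beyond the scatter of two such steps. Seen from the other side, methoxy in place of fluoro also gives a larger step with trifluoromethyl on the benzyl arm, an at least 120-fold higher number from compound 2 to compound 4 (2.09 log units; beyond the scatter), which shows that the two changes do not act independently in these four compounds, though it does not show how large the true step is, given the limit, or whether the same holds for any other core in the series: the same change on two cores in this assay, a 22-fold higher number (1.35 log units; beyond the scatter) from compound 1 to compound 3 and an at least 120-fold higher number (2.09 log units; beyond the scatter) from compound 2 to compound 4, at least 5.5-fold (0.74 log units) apart, beyond the scatter of two such steps.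

The compounds shown leave open whether this steeper loss belongs to methoxy itself or would also appear with a hydroxyl, an ethoxy or a dimethylamino group in its place. They also leave open whether bromo, methyl or a nitrile on the benzyl arm would be tolerated on the methoxy-bearing core.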